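A few compounds are considered here, and "the series" means these few. Any claim that something is new, unique, unknown or untested is made for them only; others in the source may bear on it.

Values in a functional assay on SGC-7901 cells (Homo sapiens) for antiproliferative activity, read by MTT assay, with a stated time of 48 h (on this read-out lower numbers stand for stronger inhibition and higher numbers for weaker inhibition), so far:
compound 1 `COc1ccccc1-c1nnc(SCc2ccc(Cl)nc2)o1` gives 8.2 ug/mL
compound 2 `CCOc1ccccc1-c1nnc(SCc2ccc(Cl)nc2)o1` gives 10.3 ug/mL
compound 3 `CCOc1ccc(-c2nnc(SCc3ccc(Cl)nc3)o2)cc1` gives 4.97 ug/mL

Compound 1 lies within the scatter of both others, with compound 2 nearest and compound 3 furthest. The next step leads to compound 4 `Clc1ccc(CSc2nnc(-c3ccccc3Cl)o2)cn1`, with chloro in place of methoxy on an aromatic carbon and nothing else changed. For the measured compounds named here, only one measured step offers any guide: a 1.3-fold higher number from compound 1 to compound 2 (0.10 log units; within the scatter). That step adds methyl on the saturated chain and does not remove the group. Going by the values given here, no measured compound carries chloro on that carbon, so the guide is weak. No shift beyond the scatter is expected in this assay, and the estimated change is a 1.0-fold lower number from compound 1 to compound 4 (0.01 log units; within the scatter) in either direction. For compound 4 the expected value is 8 ug/mL, with an estimated range from 3 ug/mL to 20 ug/mL here.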

Compound 4, half-maximal inhibitory concentration: 13.5 ug/mL
Compound 4: middle estimate off by 1.7-fold (0.23 log units), on the low side; low and high end bracket the measured number.
By their numbers in this assay, from the lowest: compounds 3, 1, 2 and 4 (each within the scatter of the next, the first and the last beyond it).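

In this assay, the aromatic carbon ortho to a large group now carries a group without oxygen: chloro in place of methoxy gives a 1.6-fold higher number from compound 1 to compound 4 (0.22 log units; within the scatter), and chloro in place of ethoxy gives a 1.3-fold higher number from compound 2 to compound 4 (0.12 log units; within the scatter). Neither step leaves the scatter, so removing the oxygen-linked group at this carbon has no resolved effect on this read-out. No evidence is available to explain these steps.

Still open, on these data alone, is whether an amine or a carboxylic acid on this carbon would give a step beyond the scatter.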